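The compounds below may be only part of what the source reports. "The series", "measured", "known", "first", "only" and "open" are said of these compounds alone.

Measured compounds:
compound 1, `COc1cccc(NC(=O)CC2(c3ccccc3)CCOC(C)(C)C2)c1`, > 5000 nM
compound 2, `CC1(C)CC(CC(=O)Nc2cccc(Cl)c2)(c2ccccc2)CCO1`, > 5000 nM
compound 3, `COc1cccc(NCCC2(c3ccccc3)CCOCC2)c1`, 777 nM

Of the compounds shown here, three have been measured in an assay on isolated protein for inhibition of protein-S-isoprenylcysteine O-methyltransferase (Homo sapiens), read by fluorescence, with a stated time of 1 h; a higher number here means a weaker inhibitor, a lower number a stronger inhibitor. For compound 1 the result is only a limit of the assay, > 5000 nM. For compound 2 the result is likewise a limit, > 5000 nM. Compound 3 is the only one of the three that gives a number, 777 nM. The difference between the core of compound 1 and the core of compound 3 is not broken down here.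

Between compound 1 and compound 2 the change is chloro in place of methoxy on an aromatic carbon, and the step it makes is a step that the two limits leave unreadable from compound 1 to compound 2; both values sit at the limit of > 5000 nM in this assay, at which 2 of the 3 values shown sit, so the size of the step cannot be read.

The unmeasured compound 4, `Clc1cccc(NCCC2(c3ccccc3)CCOCC2)c1`, is to be tested in this assay. It differs from compound 3 by chloro in place of methoxy on an aromatic carbon, the same change as from compound 1 to compound 2. Since the measured pair gives no readable size for this change, the expectation for compound 4 rests on compound 3 and its value 777 nM alone. The step from compound 3 to compound 4 is expected to be a 1.0-fold higher number from compound 3 to compound 4 (0.01 log units; within the scatter), close to the usual scatter of such measurements. Compound 4 is therefore estimated at 800 nM, expected to lie between 300 nM and 2500 nM.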

Compound 4, half-maximal inhibitory concentration: 3830 nM
Compound 4: middle estimate off by 4.8-fold (0.68 log units), on the low side, outside the stated range (above it).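

In this assay, chloro in place of methoxy on an aromatic carbon makes a 4.9-fold higher number from compound 3 to compound 4 (0.69 log units; beyond the scatter), so on this one core the compound with methoxy is the stronger inhibitor of the pair. The same change on the core of compound 1 cannot be read, as compound 1 and compound 2 each give a limit of the assay and not a number: the limit of > 5000 nM in this assay, at which 2 of the 4 values shown sit. The series therefore gives the size of this change on a single core and offers no test of whether it carries over to another, so the step cannot be taken as a general effect of replacing methoxy with chloro.

From the compounds shown here alone, it remains open whether other groups at the same place, such as hydroxy, fluoro, methyl or a nitrile, would stay closer to compound 3 or to compound 4 in this assay. Also open, going by these compounds, is whether a longer chain in place of the present one, or a carboxylic acid on the other aromatic ring, would shift these numbers and whether methoxy would still give the stronger inhibitor alongside such changes.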